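Quinolin-2-yl amide in a bis-indole nitrile series

The compounds below may be only part of what the source reports. "The series", "measured", "known", "first", "only" and "open" are said of these compounds alone.

Measured so far:
Compound 1, `CN1[C@@H]2c3[nH]c4ccccc4c3C[C@H]1[C@H](C#N)N1[C@@H](CNC(=O)c3cccc(C(F)(F)F)c3)c3[nH]c4ccccc4c3C[C@@H]21`, gives 870 nM in a functional assay on BGC-823 cells (Homo sapiens) for cytotoxicity, read by MTT assay, with a stated time of 72 h; a lower number here means a stronger inhibitor, a higher number a weaker inhibitor.
Compound 2, `CCc1ccc(C(=O)NC[C@H]2c3[nH]c4ccccc4c3C[C@H]3[C@H]4c5[nH]c6ccccc6c5C[C@@H]([C@H](C#N)N23)N4C)cc1`, gives 660 nM in this assay.

Compound 2 is separated from compound 1 only by a 1.3-fold lower number from compound 1 to compound 2 (0.12 log units; within the scatter), so the two measured compounds sit within the scatter of each other and neither can be called the stronger. Compound 3, `CN1[C@@H]2c3[nH]c4ccccc4c3C[C@H]1[C@H](C#N)N1[C@@H](CNC(=O)c3ccc4ccccc4n3)c3[nH]c4ccccc4c3C[C@@H]21`, has not yet been measured. It differs from compound 2 by quinolin-2-yl in place of 4-ethylphenyl on a carbonyl carbon. Among the compounds with values here, the one step that bears on this position is the exchange of the aryl group on the carbonyl carbon, a 1.3-fold lower number from compound 1 to compound 2 (0.12 log units; within the scatter), which did not move the number beyond the scatter. On that single precedent, compound 3 is expected to stay close to compound 2, with a step of about a 1.1-fold higher number from compound 2 to compound 3 (0.03 log units; within the scatter) and no change beyond the scatter predicted. Compound 3 is therefore estimated at 700 nM, within a range from 250 nM to 2000 nM.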

Compound 3, half-maximal inhibitory concentration: 80 nM
Compound 3: middle estimate off by 8.8-fold (0.94 log units), on the high side, outside the stated range (below it).
By their numbers in this assay, from the lowest: compound 3; then compounds 2 and 1 (each within the scatter of the next).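

The aryl group on the carbonyl carbon turns out not to be a silent position in this assay: quinolin-2-yl in place of 4-ethylphenyl gives an 8.3-fold lower number from compound 2 to compound 3 (0.92 log units; beyond the scatter), and the same group in place of 3-(trifluoromethyl)phenyl gives an 11-fold lower number from compound 1 to compound 3 (1.04 log units; beyond the scatter), whereas the two earlier groups stayed within the scatter of each other. Compared with 4-ethylphenyl, quinolin-2-yl adds a six-membered aromatic ring with one nitrogen and one hydrogen-bond acceptor, so these features change together in a single step. Nothing available explains the gain.

The compounds shown leave open whether the second ring or the ring nitrogen carries the step: a naphthalen-2-yl group, with two rings and no nitrogen, and a pyridin-2-yl group, with the nitrogen and one ring, would bear on that. As far as these compounds go, how a methoxy group or an amine on the quinoline would read also remains open.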